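The source may report more compounds than this note shows. Statements on the series, on what has been measured and on what is new or still open speak of the compounds shown alone.

Measured in an assay on isolated protein for inhibition of protein kinase C zeta type (Homo sapiens), with stated times of 1 h and 2.5 min, tested at 30 uM; a lower number here means less inhibition, a higher number more inhibition at the concentration tested (going by the name of the read-out):
Compound 1 `CCOC(=O)c1c(-c2ccc(OC)c(OC)c2)csc1N`: 100%
Compound 2 `CCOC(=O)c1c(-c2ccc(OC)c(OC)c2)csc1N(C)C`: 60%

Compound 1 stands highest of the two numbers, with compound 2 nearest after the step of a number 40 percentage points lower from compound 1 to compound 2 (beyond the scatter). Compound 3 `CCOC(=O)c1c(-c2cccc(OC)c2)csc1N` differs from compound 1 by hydrogen in place of methoxy on an aromatic carbon. Going by the values given here, the only measured step, a number 40 percentage points lower from compound 1 to compound 2 (beyond the scatter), alters the amino group rather than the methoxy, so it gives no direct guide; it shows only that changes on this core can move the read-out a long way. With compound 1 already at the top of the scale, the step is expected to be a number 20 percentage points lower from compound 1 to compound 3 (beyond the scatter). Compound 3 is estimated at 80%, within 45% to 100%.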

Compound 3, a percentage reported as inhibition, at one concentration (the size of the read-out at that concentration, not a potency): 82%
The estimate for compound 3 lay 2 percentage points below the measured number, and the stated range covers the measured number.
By their numbers in this assay, from the lowest: compound 2; then compound 3; then compound 1.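

Hydrogen in place of methoxy, at the site ortho to a methoxy group and para to a large group, gives a number 18 percentage points lower from compound 1 to compound 3 (beyond the scatter) in this assay, so the read-out also responds to a change on the six-membered aromatic ring and not only at the amino group. Even so, compound 3 keeps 82% with a single methoxy left on that ring. Nothing measured here accounts for this step.

The compounds shown leave open how a hydroxyl, an ethoxy group or a fluorine would fare at this site. They also leave open what losing the remaining methoxy would do.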